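From 4-methylphenyl to 4-cyanophenyl in compound 2

A few compounds are considered here, and "the series" means these few. Any claim that something is new, unique, unknown or untested is made for them only; others in the source may bear on it.

Compound 1 `Cc1ccc(S(=O)(=O)N2C/C(=C\c3cccnc3)C(=O)/C(=C/c3ccccc3F)C2)cc1`: 10300 nM
Compound 2 `Cc1ccc(S(=O)(=O)N2C/C(=C\c3cccnc3)C(=O)/C(=C/c3ccccc3C(F)(F)F)C2)cc1`: 6700 nM

Among the measured compounds shown here, compound 2 stands level with the only other measured compound in a functional assay on SMMC-7721 cells (Homo sapiens) for cytotoxicity, read by MTT assay, with a stated time of 24 h; a lower number here means a stronger inhibitor, a higher number a weaker inhibitor. For the measured compounds named here, the one measured step, a 1.5-fold lower number from compound 1 to compound 2 (0.19 log units; within the scatter), is trifluoromethyl in place of fluoro, a different change from the one at issue here. Compound 3 `N#Cc1ccc(S(=O)(=O)N2C/C(=C\c3cccnc3)C(=O)/C(=C/c3ccccc3C(F)(F)F)C2)cc1` carries cyano in place of methyl on an aromatic carbon, para to a large group: cyano in place of methyl on an aromatic carbon. Going by the values given here, no measured step tests this change, so no shift beyond the scatter is expected. The estimated step is a 1.2-fold lower number from compound 2 to compound 3 (0.09 log units; within the scatter). Compound 3 is expected at 5500 nM, with an estimated range of 2200 nM to 13000 nM.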

Compound 3, half-maximal inhibitory concentration: 9650 nM
Estimate against measurement, compound 3: 1.8-fold (0.24 log units) below; the range from low to high includes it.
By their numbers in this assay, from the lowest: compounds 2, 3 and 1 (each within the scatter of the next).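

Cyano in place of methyl, on an aromatic carbon para to a large group, gives a 1.4-fold higher number from compound 2 to compound 3 (0.16 log units; within the scatter) in this assay, so this position accepts the change without a shift beyond the scatter. With the fluoro to trifluoromethyl step, the series now has two single changes, at two different places, that both stay within the scatter. No measured evidence bears on the result.

On these data alone, whether an amine or a carboxylic acid at this position would move the number beyond the scatter stays open. Also open, as far as these compounds go, is whether cyano gives the same result on the core of compound 1, which carries fluoro rather than trifluoromethyl.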